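The source may report more compounds than this note shows. Statements on the series, on what has been measured and on what is new or still open speak of the compounds shown alone.

Measured so far:
- compound 1 `CCCCCCCCOc1ccc(NC(=O)Oc2ccccc2F)cc1`: 19 nM
- compound 2 `CCOc1ccc(NC(=O)O/N=C/c2ccccc2)cc1`: 81 nM

In an assay on H4 cells for inhibition of Fatty-acid amide hydrolase 1 (Homo sapiens) (a lower number here means a stronger inhibitor, a higher number a weaker inhibitor), compound 2 gives the higher of the two numbers, and compound 1 gives the lower, a gap that is beyond the usual scatter. For the measured compounds named here, compound 1 and compound 2 differ in more than one place, so no single step between them can be read off.

Compound 3 `CCCCCCCCCCOc1ccc(NC(=O)O/N=C/c2ccccc2)cc1` has not been measured. It differs from compound 2 in one place: octyl in place of hydrogen on a saturated chain carbon, two bonds along the chain from an oxygen on an aromatic ring. The rest of compound 2 is kept, including the oxime carbamate.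

Expectation for this assay: a step downward, beyond the scatter, is expected from compound 2 to compound 3. The only support within the series is indirect: compound 1, which carries the long chain on the aromatic oxygen, gives 19 nM, while compound 2 with its short chain gives 81 nM, and the change to compound 3 lengthens the chain in the same direction. The step is expected to be about a 5.4-fold lower number from compound 2 to compound 3 (0.73 log units; beyond the scatter). Compound 3 is therefore estimated at 15 nM, within a range from 4 nM to 60 nM.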

Compound 3, half-maximal inhibitory concentration: 0.35 nM
Compound 3: the middle estimate sits 43-fold (1.63 log units) above what was measured; the measured number lies below the stated range.
By their numbers in this assay, from the lowest: compound 3; then compound 1; then compound 2.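

In this assay, octyl in place of hydrogen on a saturated chain carbon, two bonds along the chain from an oxygen on an aromatic ring, gives a 230-fold lower number from compound 2 to compound 3 (2.36 log units; beyond the scatter) with the oxime carbamate kept, so this position takes a group of 8 heavy atoms and the number falls sharply. For the compounds shown here, this is the first change confined to one place: compound 1 and compound 2 differ in more than one place, so the effect of the chain could not be separated there, whereas here the whole step belongs to the chain. Nothing measured among the compounds shown accounts for the size of this step.

From the compounds shown here alone, whether the number falls gradually through chains shorter than octyl or drops abruptly at some length remains open, as does the reading for a longer chain or for a chain carrying an amine at this position. Also open, going by these compounds, is whether octyl at this position gives a step of similar size when the oxime carbamate is replaced by the carbamate of compound 1.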